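The source may hold more compounds than are shown below. What is called first, only, known or untested is meant among the compounds shown, and "the series" means these compounds.

Among the three compounds measured in a functional assay on A549 cells (Homo sapiens) for cytotoxicity, read by CCK-8 assay, with a stated time of 72 h (a lower number here means a stronger inhibitor, a higher number a weaker inhibitor), compound 2 `C=CCn1c(=O)/c(=C\c2cccc(F)c2)[nH]c(=O)/c1=C\c1ccccc1OC` gives the highest number, 19700 nM. Compound 3 `COc1ccccc1/C=c1\c(=O)[nH]/c(=C/c2ccccc2Cl)c(=O)n1C` gives 300 nM, and compound 1 `COc1ccccc1/C=c1\c(=O)[nH]/c(=C/c2cccc(Cl)c2Cl)c(=O)n1C` gives 200 nM, both far stronger than compound 2. Among the measured compounds shown here, the only single-point step in these data, a 1.5-fold higher number from compound 1 to compound 3 (0.18 log units; within the scatter), concerns a chloro on a different ring and stays within the scatter. The unmeasured compound 4 `C=CCn1c(=O)/c(=C\c2ccccc2OC)[nH]c(=O)/c1=C\c1ccccc1OC` differs from compound 2 by 2-methoxyphenyl in place of 3-fluorophenyl on a double-bonded chain carbon bound to an aromatic carbon. For the measured compounds named here, no measured step involves a 3-fluorophenyl or a 2-methoxyphenyl at this place, so the data give no direct guide to its size or direction. Compound 4 is therefore expected near compound 2, with a wide range, so that a 1.3-fold lower number from compound 2 to compound 4 (0.12 log units; within the scatter) is estimated as the step; the estimate for compound 4 is 15000 nM, between 3000 nM and 70000 nM.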

Compound 4, half-maximal inhibitory concentration: 22400 nM
The estimate for compound 4 lay 1.5-fold (0.17 log units) below the measured number; measured number inside the range.
By their numbers in this assay, from the lowest: compounds 1 and 3 (each within the scatter of the next); then compounds 2 and 4 (each within the scatter of the next).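

Putting 2-methoxyphenyl in place of 3-fluorophenyl on a double-bonded chain carbon bound to an aromatic carbon gives a 1.1-fold higher number from compound 2 to compound 4 (0.06 log units; within the scatter) in this assay. This position therefore tolerates this exchange without a readable shift in the number, even though the entering group carries a hydrogen-bond acceptor that the leaving group lacks. No measurement here offers an explanation for this result.

Going by these compounds, it remains open whether any group at this place can move the number beyond the scatter. A phenyl ring carrying an amine or a carboxylic acid would be one test of that.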